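This account rests on a few compounds, and the source may have more. Where it says the series, first, only, none or still open, it means among the compounds named here.

Measured so far:
compound 1 `COc1cc(OC)c(OC)cc1/C=C/C(=O)c1ccc(OC)c2c1OC(C)(C)C=C2` — > 10000 nM
compound 2 `COc1ccc(C(=O)/C=C/c2ccc([N+](=O)[O-])cc2)c2c1C=CC(C)(C)O2` — 3420 nM

In a functional assay on SK-OV-3 cells (Homo sapiens) for antiproliferative activity, read by MTT assay, with a stated time of 24 h (on this read-out higher numbers stand for weaker inhibition and lower numbers for stronger inhibition), compound 1 gives only a limit, > 10000 nM. Among the compounds with values here, compound 2 gives 3420 nM in this assay, the only number in the set. The other entry, that of compound 1, is the limit of > 10000 nM in this assay, at which 1 of the 2 values shown sits.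

Compound 3 `COc1ccc(C(=O)/C=C/c2ccc(O)cc2)c2c1C=CC(C)(C)O2` is not yet measured. It differs from compound 2 by hydroxy in place of nitro on an aromatic carbon. Within the data shown here, no measured step covers this change, so the expectation rests on compound 2 alone. The step from compound 2 to compound 3 in this assay is expected to be a 1.5-fold higher number from compound 2 to compound 3 (0.16 log units; within the scatter), a modest weakening that may not exceed the scatter. Compound 3 is expected to give about 5000 nM in this assay, between 1500 nM and 15000 nM.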

Compound 3, half-maximal inhibitory concentration: > 10000 nM
Compound 3 was reported as a limit; the forecaster's own chance of this, stated with the estimate: 30%; at least 2.0-fold (0.30 log units) between middle value and limit.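

In this assay, hydroxy in place of nitro at this position, para to a large group, gives an at least 2.9-fold higher number from compound 2 to compound 3 (0.46 log units; beyond the scatter), so the two groups are not interchangeable here. Compound 3 is reported as a limit and not a number, so the step gives only a minimum size. Compound 2 alone gives a number among the compounds shown, and the rest sit at the limit: the limit of > 10000 nM in this assay, at which 2 of the 3 values shown sit.

Going by these compounds, whether a number is tied to nitro specifically remains open. An amine, a nitrile or a carboxylic acid at the same place would test this.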